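The compounds below may be only part of what the source reports. "The series", "measured", "known", "first", "only" and "open" are said of these compounds alone.

Measured in a functional assay on the whole organism (strain albino) for inhibition, with Rattus norvegicus as the target, read by paw edema, with a stated time of 1 h, at a dose of 100 mg/kg by the oral route; a higher number here means more inhibition at the dose given (going by the name of the read-out), a lower number less inhibition:

Compound 1 `O=C(CSc1nc(-c2ccc(Cl)cc2)c(C(=O)O)c(=O)[nH]1)Nn1c(COc2ccc(Cl)cc2Cl)nc2ccccc2c1=O` gives 58.2%.
Compound 2 `O=C(CSc1nc(-c2ccc(O)cc2)c(C(=O)O)c(=O)[nH]1)Nn1c(COc2ccc(Cl)cc2Cl)nc2ccccc2c1=O` gives 36.4%.
Compound 3 `Cn1c(SCC(=O)Nn2c(COc3ccc(Cl)cc3Cl)nc3ccccc3c2=O)nc(-c2ccc(Cl)cc2)c(C#N)c1=O` gives 76.4%.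

Compound 2 differs from compound 1 in one place, (hydroxy in place of chloro on an aromatic carbon). That change cost a number 21.8 percentage points lower from compound 1 to compound 2 (beyond the scatter) in this assay, a modest drop that is larger than the usual scatter. Compound 3 has the highest of the three numbers; its core differs from the core of compound 1, but that difference is not broken down here. Compound 4 `Cn1c(SCC(=O)Nn2c(COc3ccc(Cl)cc3Cl)nc3ccccc3c2=O)nc(-c2ccc(O)cc2)c(C#N)c1=O` has not been measured. It stands to compound 3 as compound 2 stands to compound 1: hydroxy in place of chloro on an aromatic carbon, at the same place as before, so this is the same change seen a second time. Going by the values given here, only one earlier example of it exists, so the expectation rests on that single step. Compound 4 is expected to fall below compound 3 by about a number 20.4 percentage points lower from compound 3 to compound 4 (beyond the scatter) in this assay, because compound 1 to compound 2 showed a number 21.8 percentage points lower from compound 1 to compound 2 (beyond the scatter). The estimate for compound 4 is therefore 56%, with a likely range from 42% to 70%.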

Compound 4, a percentage reported as inhibition, in the whole organism at one dose (the size of the read-out at that dose, not a potency): 80%
Compound 4: the middle estimate sits 24 percentage points below what was measured; the whole stated range lies below it.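

On the core of compound 3, going from 4-chlorophenyl to 4-hydroxyphenyl gives a number 3.6 percentage points higher from compound 3 to compound 4 (within the scatter) in this assay, so this swap leaves no measurable mark on this core. Set beside the earlier step, the same swap clearly behaves differently on the two cores: the same change on two cores in this assay, a number 21.8 percentage points lower (beyond the scatter) from compound 1 to compound 2 and a number 3.6 percentage points higher (within the scatter) from compound 3 to compound 4, 25.4 percentage points apart, beyond the scatter of two such steps This shows that the drop seen on the core of compound 1 cannot simply be carried over to another core in this series, but it does not show which feature of the cores decides the outcome, and each core offers only a single pair of compounds.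

The compounds shown leave open whether a methoxy group or an amine in the same place on the ring would follow the pattern of the core of compound 1 or that of compound 3. Also open, as far as these compounds go, is which core feature matters, the nitrile in place of the carboxylic acid or the methyl on the ring nitrogen.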